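The source may hold more compounds than are shown below. What is called first, only, known or untested is meant among the compounds shown, and "the series" means these compounds.

Values so far in a functional assay on HeLa cells (Homo sapiens) for inhibition, read by CCK-8 assay, with a stated time of 48 h (on this read-out higher numbers stand for weaker inhibition and lower numbers for stronger inhibition), are these:
- compound 1 `COc1cc(-c2ccnc3cc(-c4ccc(F)cc4)nn23)cc(OC)c1OC` at 5840 nM
- compound 2 `COc1cc(-c2ccnc3cc(-c4ccccc4)nn23)cc(OC)c1OC` at 458 nM
- compound 3 `COc1cc(-c2ccnc3cc(-c4cccc(C)c4)nn23)cc(OC)c1OC` at 4230 nM

Compound 3 at 4230 nM stands level with compound 1 within the scatter, with a 1.4-fold lower number from compound 1 to compound 3 (0.14 log units; within the scatter) between them. The gap to compound 2 is clear, with a 9.2-fold higher number from compound 2 to compound 3 (0.97 log units; beyond the scatter) on record.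

The next change leads to compound 4 `COc1ccc(-c2cc3nccc(-c4cc(OC)c(OC)c(OC)c4)n3n2)cc1` with 4-methoxyphenyl in place of 3-methylphenyl on an aromatic carbon as the only difference.

Two other steps bear on it. Hydrogen in place of fluoro gave a 13-fold lower number from compound 1 to compound 2 (1.11 log units; beyond the scatter) and is large. Methyl in place of hydrogen gave a 9.2-fold higher number from compound 2 to compound 3 (0.97 log units; beyond the scatter) and is modest. Among these three, only compound 2 has an unsubstituted phenyl and gives the low number, and no compound goes against this. Among the measured compounds shown here, compound 4 keeps a substituted phenyl, so it is expected to stay with compound 1 and compound 3, though no measured compound carries methoxy on that ring. No step beyond the scatter is expected in this assay, and the estimated step is a 1.4-fold lower number from compound 3 to compound 4 (0.15 log units; within the scatter) as a working figure. For compound 4 the estimate is 3000 nM with an expected range from 600 nM to 10000 nM in this read-out.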

Compound 4, half-maximal inhibitory concentration: 373 nM
Estimate against measurement, compound 4: 8.0-fold (0.91 log units) above, outside the stated range (below it).
By their numbers in this assay, from the lowest: compounds 4 and 2 (each within the scatter of the next); then compounds 3 and 1 (each within the scatter of the next).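

In this assay, a substituted phenyl at this position no longer goes with the high number: 4-methoxyphenyl in place of 3-methylphenyl gives an 11-fold lower number from compound 3 to compound 4 (1.05 log units; beyond the scatter), and methoxy in place of fluoro gives a 16-fold lower number from compound 1 to compound 4 (1.19 log units; beyond the scatter). Methoxy in place of hydrogen gives a 1.2-fold lower number from compound 2 to compound 4 (0.09 log units; within the scatter), so a substituted phenyl here can sit level with the unsubstituted one, and the high numbers belong only to the 4-fluorophenyl and 3-methylphenyl groups. Nothing on hand offers an explanation for these differences.

From the compounds shown here alone, what 4-methylphenyl or 3-methoxyphenyl would give remains open, so the step from 3-methylphenyl cannot be divided between the change of group and its place on the phenyl ring. Going by these compounds, whether 4-aminophenyl or 4-ethoxyphenyl would keep the low number is also open.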